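Will a second ethyl group lower the number again?

This account rests on a few compounds, and the source may have more. Where it says the series, first, only, none or still open, it means among the compounds named here.

compound 1 `Cc1noc(C)c1[C@@H]1C[C@@](C)(c2ccc(F)cc2F)N=C(N)S1`: 78%
compound 2 `Cc1noc(C)c1[C@@H]1C[C@@](C)(c2sccc2Cl)N=C(N)S1`: 12%
compound 3 `CCc1noc(C)c1[C@@H]1C[C@@](C)(c2ccc(F)cc2F)N=C(N)S1`: 59%

All three numbers come from an ADME assay on microsomes from liver (Rattus norvegicus) for metabolic stability, with a stated time of 10 min, tested at 0.5 uM; on this read-out lower numbers stand for a less stable compound and higher numbers for a more stable compound. Among them, compound 3, at 59%, stands second highest. Compound 1 lies higher and compound 2 lower, and both gaps go beyond the usual scatter of repeated measurements.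

The next compound, compound 4 `CCc1noc(CC)c1[C@@H]1C[C@@](C)(c2ccc(F)cc2F)N=C(N)S1`, differs from compound 3 in one place: methyl in place of hydrogen on a saturated chain carbon bound to an aromatic carbon. In words, this is methyl in place of hydrogen on a saturated chain carbon bound to an aromatic carbon, so a methyl becomes an ethyl. Within the data shown here, only one measured step is of the same kind, and it shows a number 19 percentage points lower from compound 1 to compound 3 (beyond the scatter). Among the measured compounds shown here, compound 2 carries a different aromatic group and offers no step of this kind. A single example is thin evidence, so the size of the next step is uncertain, but a drop of similar size in this assay is the reasonable expectation. The expected change is a number 17 percentage points lower from compound 3 to compound 4 (beyond the scatter). For compound 4 the estimated value is 42%, with an expected range from 22% to 60%.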

Compound 4, percent of the compound remaining: 67%
Compound 4: middle estimate off by 25 percentage points, on the low side; measured number above the stated range.
By their numbers in this assay, from the lowest: compound 2; then compounds 3 and 4 (each within the scatter of the next); then compound 1.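

In this assay, the same change, methyl in place of hydrogen on a saturated chain carbon bound to an aromatic carbon, turns out not to carry a fixed cost. Turning the first methyl into an ethyl gave a number 19 percentage points lower from compound 1 to compound 3 (beyond the scatter), while turning the other methyl into an ethyl gave a number 8 percentage points higher from compound 3 to compound 4 (within the scatter) with the first ethyl already present. One step of this kind therefore does not predict the next, and the two methyl groups of the core cannot be treated as interchangeable on this read-out.

Still open, going by these compounds, is how far this tolerance extends at the second position: a longer chain such as propyl, or a group of another kind such as an amine or a carboxylic acid, could behave differently there, and the same change could also read differently with the aromatic group of compound 2 in place. No measurement shown here accounts for the difference between the two steps.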